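Expecting the Next Compound From Three Weak Inhibitors

The source may hold more compounds than are shown below. What is called first, only, known or untested is meant among the compounds shown, and "the series" means these compounds.

Compound 1 `COc1ccc(/C=N/Nc2nc3ccccc3nc2Cc2ccccc2)cc1OC`: 460000 nM
Compound 2 `C/C(=N\Nc1nc2ccccc2nc1Cc1ccccc1)c1ccccc1`: 980000 nM
Compound 3 `C/C(=N\Nc1nc2ccccc2nc1Cc1ccccc1)c1ccccn1`: 980000 nM

All three were tested in an assay on isolated protein for inhibition of Amine oxidase [flavin-containing] B (Homo sapiens), read by spectrophotometry; on this read-out higher numbers stand for weaker inhibition and lower numbers for stronger inhibition. Compound 3 stands level with compound 2, the two together giving the highest numbers of the three; compound 1 alone gives a lower number, and that gap lies beyond the scatter. Among the measured compounds shown here, the one single-point step is flat: no change at the digits printed from compound 2 to compound 3 (within the scatter). Compound 4 `Brc1cccc(/C=N/Nc2nc3ccccc3nc2Cc2ccccc2)c1` carries a group of 9 heavy atoms (7 carbon, 1 nitrogen, 1 bromine; one six-membered aromatic ring of carbon only) in place of a group of 9 heavy atoms (7 carbon, 2 nitrogen; one six-membered aromatic ring with 1 hetero atom), on a nitrogen on an aromatic ring. The flat step from compound 2 to compound 3 suggests the group at this nitrogen moves the number little, while compound 1, which differs from compound 4 in more than one place, shows that a change here can reach past the scatter. A small shift toward a lower number is therefore expected, a 1.6-fold lower number from compound 3 to compound 4 (0.21 log units; within the scatter). Compound 4 is estimated at 600000 nM, ranging from 250000 nM to 1500000 nM.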

Compound 4, half-maximal inhibitory concentration: 48000 nM
Beside the measured number, compound 4's estimate is 13-fold (1.10 log units) above it; the measured number lies below the stated range.
By their numbers in this assay, from the lowest: compound 4; then compound 1; then compounds 2 and 3 (each within the scatter of the next).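

The group on the nitrogen on an aromatic ring matters more than the flat earlier step suggested: in this assay, the group carrying bromine gives a 20-fold lower number from compound 3 to compound 4 (1.31 log units; beyond the scatter) and a 20-fold lower number from compound 2 to compound 4 (1.31 log units; beyond the scatter). With only the aromatic group changed, 3-bromophenyl in place of 3,4-dimethoxyphenyl still gives a 9.6-fold lower number from compound 1 to compound 4 (0.98 log units; beyond the scatter). Nothing measured here offers a reason for these drops. On these data alone, whether the drop depends on the bromine itself or on where it sits on the ring stays open. So does what a chlorine or a nitrile in its place would give.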